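Chloro for Amino on a Fused Dichloro Core

A few compounds are considered here, and "the series" means these few. Any claim that something is new, unique, unknown or untested is made for them only; others in the source may bear on it.

Compound 1 `ClCc1ccc(Cn2cnc3c(Cl)ncnc32)cc1`: 21400 nM
Compound 2 `Nc1nc(Cl)c2ncn(Cc3ccc(CCl)cc3)c2n1`: > 100000 nM

In a functional assay on 786-0 cells (Homo sapiens) for cytotoxicity, read by sulforhodamine B assay, with a stated time of 48 h (a higher number here means that more compound is tolerated, a lower number that less compound is tolerated), compound 1 gives 21400 nM. Compound 2 sits at the assay limit (the limit of > 100000 nM in this assay, at which 1 of the 2 values shown sits), so for compound 2 the value > 100000 nM is a limit rather than a number. For the measured compounds named here, the only measured step is an at least 4.6-fold higher number from compound 1 to compound 2 (0.66 log units; beyond the scatter). Compound 3 `ClCc1ccc(Cn2cnc3c(Cl)nc(Cl)nc32)cc1` carries the change (chloro in place of amino on an aromatic carbon). Because the amino added in an at least 4.6-fold higher number from compound 1 to compound 2 (0.66 log units; beyond the scatter) is removed again, the number for compound 3 is expected to fall, as an at least 3.3-fold lower number from compound 2 to compound 3 (0.52 log units; beyond the scatter) shows. The estimate for compound 3 is 30000 nM, with a range from 8000 nM to 100000 nM.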

Compound 3, concentration lethal to 50% of the cells: 61700 nM
Compound 3: middle estimate off by 2.1-fold (0.31 log units), on the low side; measured number inside the range.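

Chloro in place of hydrogen at this position, between two ring nitrogen atoms, gives in this assay a 2.9-fold higher number from compound 1 to compound 3 (0.46 log units; beyond the scatter) as well, so amino is not the only group here that raises the number over hydrogen. Chloro in place of amino gives an at least 1.6-fold lower number from compound 2 to compound 3 (0.20 log units; that floor lies within the scatter) and so leaves chloro and amino unordered. The value of compound 2 is a limit and not a number: the limit of > 100000 nM in this assay, at which 1 of the 3 values shown sits.

What the compounds shown leave open is how a methoxy group or a dimethylamino group at this position would read.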